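This account rests on a few compounds, and the source may have more. Where it says the series, first, only, none or still open, it means among the compounds named here.

Measured in a functional assay on HeLa cells (Homo sapiens) for antiproliferative activity, read by MTT assay, with a stated time of 48 h; on this read-out lower numbers stand for stronger inhibition and higher numbers for weaker inhibition:
- Compound 1 `CN(C)CCn1c(N)c(-c2nc3ccccc3n2C)c2nc(C#N)c(C#N)nc21`: > 50000 nM, a limit of the assay
- Compound 2 `CCN(CC)CCCn1c(N)c(-c2nc3ccccc3n2C)c2nc(C#N)c(C#N)nc21`: 12400 nM
- Compound 3 `CCN(CC)CCCCn1c(N)c(-c2nc3ccccc3n2C)c2nc(C#N)c(C#N)nc21`: 1610 nM

Compound 2 holds the highest of the two exact numbers, and the third value is a limit. The nearest number lies at a 7.7-fold lower number from compound 2 to compound 3 (0.89 log units; beyond the scatter).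

The next compound to be tested is compound 4 `CCN(CC)CCCn1c(N)c(-c2nc3cc(Cl)ccc3[nH]2)c2nc(C#N)c(C#N)nc21`, which keeps the 3-(diethylamino)propyl group of compound 2. It carries 5-chloro-1H-benzimidazol-2-yl in place of 1-methyl-1H-benzimidazol-2-yl on an aromatic carbon.

Among the compounds with values here, no measured step touches this place. The measured steps all change the chain and its amine: an at least 4.0-fold lower number from compound 1 to compound 2 (0.60 log units; beyond the scatter), an at least 31-fold lower number from compound 1 to compound 3 (1.49 log units; beyond the scatter) and a 7.7-fold lower number from compound 2 to compound 3 (0.89 log units; beyond the scatter). They therefore show only how far this assay can move within this small set, and they give no direct guide to the new exchange.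

A modest move toward a lower number is expected, smaller than a 7.7-fold lower number from compound 2 to compound 3 (0.89 log units; beyond the scatter), though the direction remains uncertain. The estimated change is a 2.5-fold lower number from compound 2 to compound 4 (0.39 log units; beyond the scatter). The estimate for compound 4 is 5000 nM, with an expected range from 1000 nM to 25000 nM.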

Compound 4, half-maximal inhibitory concentration: 24400 nM
The estimate for compound 4 lay 4.9-fold (0.69 log units) below the measured number; measured number inside the range.
By their numbers in this assay, from the lowest: compound 3; then compounds 2 and 4 (each within the scatter of the next). At a limit, above all of these: compound 1.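

In this assay, within the data shown here, the exchange of 1-methyl-1H-benzimidazol-2-yl for 5-chloro-1H-benzimidazol-2-yl gives a 2.0-fold higher number from compound 2 to compound 4 (0.29 log units; within the scatter), the first reading at this aromatic carbon. The earlier steps shown here, all on the chain and its amine, lay beyond the scatter, whereas this exchange, which takes away the methyl group and brings in a chlorine and a hydrogen-bond donor, produces no change that can be told apart from the scatter. No information given here bears on why this exchange behaves as it does.

The two parts of the exchange remain unseparated: a plain 1H-benzimidazol-2-yl group, or a 5-chloro-1-methyl-1H-benzimidazol-2-yl group, would show what each contributes. As far as these compounds go, it also remains open whether 5-chloro-1H-benzimidazol-2-yl would give the same result on the longer chain of compound 3.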